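A few compounds are considered here, and "the series" means these few. Any claim that something is new, unique, unknown or untested is made for them only; others in the source may bear on it.

Measured compounds:
compound 1 `COc1cc(C(=O)O)ccc1OCCCCOc1ccc(C(=O)CC(C)C)c(O)c1C` — 73.9%
compound 2 `Cc1c(OCCCCOc2ccc(C(=O)O)cc2)ccc(C(=O)CC(C)C)c1O` — 51.9%
compound 3 `Cc1c(OCCCCOc2ccc(C(=O)O)cc2)ccc(C(=O)CC2CCCC2)c1O` — 26.7%

In an assay on HEK293 cells for positive allosteric modulation of metabotropic glutamate receptor 3 (Rattus norvegicus), read by thallium flux, with a stated time of 2.5 min (on this read-out lower numbers stand for smaller maximal responses and higher numbers for larger maximal responses), compound 3 gives the lowest of the three numbers. The nearest measured compound is compound 2, at 51.9%, and the step of a number 25.2 percentage points lower from compound 2 to compound 3 (beyond the scatter) lies beyond the scatter; compound 1, at 73.9%, sits furthest away.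

Compound 4 `Cc1cc(OCCCCOc2ccc(C(=O)CC3CCCC3)c(O)c2C)ccc1C(=O)O` is not yet measured. It differs from compound 3 by methyl in place of hydrogen on an aromatic carbon of the six-membered carbon-only ring that carries the carboxy group, ortho to that carboxy group and meta to the large group.

Among the compounds with values here, no measured step changes exactly this position. Within the data shown here, the only step that touches the same ring is a number 22 percentage points lower from compound 1 to compound 2 (beyond the scatter), where removing a methoxy from an aromatic carbon of that ring lowered the maximal response. Read in reverse, putting a small group onto this ring went with a higher number, but the group and its place both differ from the present change, so the bearing is loose. The step of a number 25.2 percentage points lower from compound 2 to compound 3 (beyond the scatter) concerns the other end of the molecule and does not inform this change.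

The expectation for compound 4 is therefore a small rise in maximal response, a number 8.3 percentage points higher from compound 3 to compound 4 (within the scatter), with wide uncertainty. Compound 4 is estimated at 35%, in the range 15% to 60%.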

Compound 4, largest response reached (reported as percent of maximum), in percent of the reference or control that the assay uses: 23.7%
Compound 4: middle estimate off by 11.3 percentage points, on the high side, and the stated range covers the measured number.
By their numbers in this assay, from the lowest: compounds 4 and 3 (each within the scatter of the next); then compound 2; then compound 1.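

In this assay, methyl in place of hydrogen on an aromatic carbon ortho to the carboxy group gives a number 3 percentage points lower from compound 3 to compound 4 (within the scatter) and so leaves the maximal response of the cyclopentyl compounds at this level without a separable change. The earlier step on this ring, a number 22 percentage points lower from compound 1 to compound 2 (beyond the scatter), concerned methoxy at a different place with isopropyl at the other end of the molecule, and this new step shows that a small group on the ring does not by itself go with a change beyond the scatter. Nothing at hand explains the outcome at this position.

Still open, on these data alone, is whether the same methyl would read the same way with the isopropyl end, as in compound 2 at 51.9%, where the response is not already as low as in compound 3. Also open, as far as these compounds go, is whether another group at this place, such as fluorine, an amine or a longer chain like ethyl, would move the maximal response beyond the scatter in this assay.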